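Extending the side chain of a CXCR4 antagonist

The source may report more compounds than this note shows. Statements on the series, on what has been measured and on what is new or still open speak of the compounds shown alone.

Measured so far:
compound 1 `c1cncc(CNCCCCN(C[C@H]2Cc3ccccc3CN2)[C@H]2CCCc3cccnc32)c1` — 15.3 nM
compound 2 `NCc1ccccc1CN(C[C@H]1Cc2ccccc2CN1)[C@H]1CCCc2cccnc21` — 50.8 nM

Two compounds share a common core and differ only in the group attached to a saturated chain carbon bound to an amine nitrogen. In a functional assay on cells for antagonist activity at C-X-C chemokine receptor type 4 (Homo sapiens), read by fluorescence and calcium flux, with stated times of 25 min and 90 s (on this read-out lower numbers stand for stronger inhibition and higher numbers for weaker inhibition), compound 1 gives 15.3 nM, and compound 2 gives 50.8 nM. Among the compounds with values here, the one step measured so far, a 3.3-fold higher number from compound 1 to compound 2 (0.52 log units; beyond the scatter), shows that swapping the longer chain for the 2-(aminomethyl)phenyl group weakened inhibition. Compound 2 therefore stands as the higher of the two numbers in this assay.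

Compound 3 `C(=C/CN(C[C@H]1Cc2ccccc2CN1)[C@H]1CCCc2cccnc21)\CNCC1CCOCC1` has not yet been tested. It differs from compound 2 as follows: a group of 11 heavy atoms (9 carbon, 1 nitrogen, 1 oxygen; one six-membered non-aromatic ring with 1 hetero atom) in place of a group of 8 heavy atoms (7 carbon, 1 nitrogen; one six-membered aromatic ring of carbon only), on a saturated chain carbon bound to an amine nitrogen. The new group restores a longer chain ending in a secondary amine, as in compound 1, but closes with a six-membered non-aromatic ring with one hetero atom and carries a double bond outside aromatic rings. Within the data shown here, only the step from compound 1 to compound 2 bears on this change, and it was modest. The expected step from compound 2 to compound 3 in this assay is a 2.0-fold lower number from compound 2 to compound 3 (0.31 log units; beyond the scatter), a move back toward lower numbers. Compound 3 is estimated at 25 nM, within a range of 8 nM to 80 nM.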

Compound 3, half-maximal inhibitory concentration: 24.2 nM
The estimate for compound 3 lay 1.0-fold (0.01 log units) above the measured number; the measured number falls inside the stated range.
By their numbers in this assay, from the lowest: compounds 1 and 3 (each within the scatter of the next); then compound 2.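

In this assay, the chain of compound 3, which carries a double bond and closes with a six-membered non-aromatic ring with 1 hetero atom, gives a 2.1-fold lower number from compound 2 to compound 3 (0.32 log units; beyond the scatter), so a second long chain ending in a secondary amine now reads lower than the 2-(aminomethyl)phenyl group at this saturated chain carbon bound to an amine nitrogen. The comparison of the two long chains gives a 1.6-fold higher number from compound 1 to compound 3 (0.20 log units; within the scatter), which means that these two compounds cannot be told apart in this assay, and that an aromatic ring at the chain end is not needed for compound 3 to reach this level. No measurement at hand gives a reason for either step.

From the compounds shown here alone, compound 1 and compound 3 differ in both the end ring and the double bond, so the part played by each of these changes remains unknown. Going by these compounds, it also remains open how the same position would respond to a chain with this non-aromatic ring but no double bond, or to a long chain ending in a carboxylic acid instead of a secondary amine.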